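A few compounds are considered here, and "the series" means these few. Any claim that something is new, unique, unknown or untested is made for them only; others in the source may bear on it.

Compound 1 `COC(=O)C(c1ccccc1Cl)N1CCC(O)(Cn2cnc3c(cnn3-c3ccc(F)cc3)c2=O)CC1`: "not determined" (no result reported)
Compound 2 `O=c1c2cnn(-c3ccc(F)cc3)c2ncn1CC1(O)CCN(Cc2ccccc2Cl)CC1`: 3400 nM
Compound 3 `N#Cc1ccccc1CN1CCC(O)(Cn2cnc3c(cnn3-c3ccc(F)cc3)c2=O)CC1`: 8100 nM

Going by the values given here, in an assay on Sf21 cells for inhibition of ubiquitin carboxyl-terminal hydrolase 7 (Homo sapiens), read by spectrophotometry, with stated times of 30 min and 2 h (a lower number here means a stronger inhibitor, a higher number a weaker inhibitor), compound 3 stands at the higher of the two reported numbers, with compound 2 as its nearest neighbour; that step, a 2.4-fold higher number from compound 2 to compound 3 (0.38 log units; beyond the scatter), is the only measured step and the only one that bears on the change now considered. Compound 4 `O=c1c2cnn(-c3ccc(F)cc3)c2ncn1CC1(O)CCN(Cc2ccc(Cl)cc2Cl)CC1` differs from compound 3 in one place: 2,4-dichlorophenyl in place of 2-cyanophenyl on a saturated chain carbon bound to an amine nitrogen in a ring. Since replacing chloro by cyano raised the number by the step shown, the return from cyano to chloro, with a second chloro added, is expected to lower it by a comparable amount, roughly back to the level of compound 2. Compound 4 is therefore estimated at 2500 nM, within 800 nM to 8000 nM, an expected step of a 3.2-fold lower number from compound 3 to compound 4 (0.51 log units; beyond the scatter).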

Compound 4, half-maximal inhibitory concentration: 3300 nM
Compound 4: middle estimate off by 1.3-fold (0.12 log units), on the low side, and the stated range covers the measured number.
By their numbers in this assay, from the lowest: compounds 4 and 2 (each within the scatter of the next); then compound 3.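

In this assay, the change from 2-cyanobenzyl to 2,4-dichlorobenzyl gives a 2.5-fold lower number from compound 3 to compound 4 (0.39 log units; beyond the scatter), while chloro in place of hydrogen on an aromatic carbon gives a 1.0-fold lower number from compound 2 to compound 4 (0.01 log units; within the scatter). The added chloro thus makes no readable difference, and among the compounds shown, the nitrile-bearing compound 3 stands apart from the two chloro compounds, compound 2 and compound 4. No measurement at hand explains this result. On these data alone, it remains open whether a methoxy group or an amine on this aromatic ring would read like chloro or like nitrile. Also open, as far as these compounds go, is whether a nitrile alongside a second chloro would keep the higher number of compound 3.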